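Extending isopropyl to tert-butyl on the amine side chain

The source may report more compounds than this note shows. Statements on the series, on what has been measured and on what is new or still open speak of the compounds shown alone.

In a functional assay on SK-BR-3 cells (Homo sapiens) for antiproliferative activity (on this read-out lower numbers stand for stronger inhibition and higher numbers for weaker inhibition), compound 1 `CC(C)=CCc1cc(C(=O)Nc2cc3ccc(OCC4CCCNC4)c(C)c3oc2=O)ccc1O` gives 600 nM. Going by the values given here, compound 2 `CC(C)=CCc1cc(C(=O)Nc2cc3ccc(OCCCN(C)C(C)C)c(C)c3oc2=O)ccc1O` gives 570 nM, level with its only measured neighbour. Compound 3 `CC(C)=CCc1cc(C(=O)Nc2cc3ccc(OCCCN(C)C(C)(C)C)c(C)c3oc2=O)ccc1O` differs from compound 2 by methyl in place of hydrogen on a saturated chain carbon bound to an amine nitrogen and two saturated chain carbons, which turns isopropyl to tert-butyl on the amine side chain. Among the compounds with values here, one measured step bears on this change, and only indirectly: a 1.1-fold lower number from compound 1 to compound 2 (0.02 log units; within the scatter). That step swaps piperidin-3-yl for 2-(isopropyl(methyl)amino)ethyl, so the side chain changes far more than a single methyl would change it, yet the read-out stays within the scatter. Within the data shown here, no measured pair tests a methyl at this place, so no direction can be assigned, and no step beyond the scatter is expected in this assay. The expected step is a 1.1-fold higher number from compound 2 to compound 3 (0.02 log units; within the scatter). Compound 3 is estimated at 600 nM, with an expected range of 280 nM to 1300 nM.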

Compound 3, half-maximal inhibitory concentration: 880 nM
Compound 3: the middle estimate sits 1.5-fold (0.17 log units) below what was measured; low and high end bracket the measured number.
By their numbers in this assay, from the lowest: compounds 2, 1 and 3 (each within the scatter of the next).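

The first direct test of a methyl at this place, on a saturated chain carbon bound to an amine nitrogen and two saturated chain carbons, gives a 1.5-fold higher number from compound 2 to compound 3 (0.19 log units; within the scatter) in this assay, so isopropyl to tert-butyl leaves the read-out within the scatter. The wider swap, 2-(methyl(tert-butyl)amino)ethyl in place of piperidin-3-yl, gives a 1.5-fold higher number from compound 1 to compound 3 (0.17 log units; within the scatter), so these three side chains cannot be told apart in this read-out. Nothing at hand explains these numbers or bears on this result.

As far as these compounds go, whether a larger group such as cyclohexyl in place of tert-butyl, or a carboxylic acid in place of the amine, would carry the number beyond the scatter stays open. From the compounds shown here alone, the rest of the structure is shared by all three compounds, so the role of the remaining parts stays open as well.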